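The compounds below may be only part of what the source reports. "The series", "measured", "known", "first", "only" and "open" are said of these compounds alone.

Measured so far in an ADME assay (liver) for metabolic stability, with Liver microsome (Rattus norvegicus) as the target, using microsomes and NADPH, with a stated time of 30 min, tested at 1 uM; a lower number here means slower removal, a higher number faster removal of the compound:
- compound 1 `NC(=O)c1cccc(-c2cc(C(O)(C(F)(F)F)C(F)(F)F)cnc2N2CCN(S(=O)(=O)c3ccc(N)nc3)CC2)c1`: 63 mL.min-1.g-1
- compound 2 `Cc1ccc(-c2cc(C(O)(C(F)(F)F)C(F)(F)F)cnc2N2CCN(S(=O)(=O)c3ccc(N)nc3)CC2)cn1`: 182 mL.min-1.g-1
- compound 3 `COc1ccc(-c2cc(C(O)(C(F)(F)F)C(F)(F)F)cnc2N2CCN(S(=O)(=O)c3ccc(N)nc3)CC2)cn1`: 265 mL.min-1.g-1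

Compound 3 sits at the upper end of these numbers, level within the scatter with compound 2: a 1.5-fold higher number from compound 2 to compound 3 (0.16 log units; within the scatter). Compound 4 `Nc1ccc(S(=O)(=O)N2CCN(c3ncc(C(O)(C(F)(F)F)C(F)(F)F)cc3-c3ccc4scnc4c3)CC2)cn1` carries 1,3-benzothiazol-5-yl in place of 6-methoxypyridin-3-yl on an aromatic carbon. The modest steps at this same place, a 2.9-fold higher number from compound 1 to compound 2 (0.46 log units; beyond the scatter) and a 4.2-fold higher number from compound 1 to compound 3 (0.62 log units; beyond the scatter), both leave 3-carbamoylphenyl. That group is not involved here. Among the measured compounds shown here, the closest precedent is the exchange between compound 2 and compound 3, which stayed within the scatter. The expected result is therefore no change beyond the scatter: a 1.2-fold lower number from compound 3 to compound 4 (0.08 log units; within the scatter). Compound 4 is estimated at 220 mL.min-1.g-1, with an expected range of 100 mL.min-1.g-1 to 420 mL.min-1.g-1.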

Compound 4, intrinsic clearance in microsomes: 147 mL.min-1.g-1
Estimate against measurement, compound 4: 1.5-fold (0.18 log units) above, and the stated range covers the measured number.
By their numbers in this assay, from the lowest: compound 1; then compounds 4, 2 and 3 (each within the scatter of the next).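

In this assay a second fused ring makes no clear difference at this position: a 1.8-fold lower number from compound 3 to compound 4 (0.26 log units; within the scatter) and a 1.2-fold lower number from compound 2 to compound 4 (0.09 log units; within the scatter) both lie within the scatter, so 1,3-benzothiazol-5-yl sits level with the two single-ring pyridines. Compound 1 with its 3-carbamoylphenyl stays apart, and a 2.3-fold higher number from compound 1 to compound 4 (0.37 log units; beyond the scatter) is a third step from it beyond the scatter. No measured evidence here accounts for these numbers.

Still open, from the compounds shown here alone, is whether the carbamoyl group itself sets compound 1 apart, or whether a phenyl carrying an amine or a carboxylic acid in its place would give a similarly low number.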